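Notes on hydroxy to methoxy in a small series

A few compounds are considered here, and "the series" means these few. Any claim that something is new, unique, unknown or untested is made for them only; others in the source may bear on it.

Measured so far:
compound 1 `CCOc1ccccc1-c1nc2ccccc2[nH]1`, 50%
compound 2 `COc1cc(-c2nc3ccccc3[nH]2)ccc1O`, 70%

In a functional assay on the whole organism (ileum) with Rattus norvegicus as the target (on this read-out higher numbers stand for larger maximal responses and lower numbers for smaller maximal responses), compound 2 gives 70%, the higher of the two numbers; compound 1 gives 50%, a gap beyond the scatter. Compound 3 `COc1ccc(-c2nc3ccccc3[nH]2)cc1OC` has not yet been measured; relative to compound 2 it differs by methyl in place of hydrogen on an oxygen on an aromatic ring. Among the measured compounds shown here, no measured pair shares this change, so nothing here shows its effect. Expected is a small downward step, a number 10 percentage points lower from compound 2 to compound 3 (within the scatter), near the edge of the scatter. Compound 3 is accordingly estimated at 60%, with a range from 35% to 85%.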

Compound 3, largest response reached (Emax), in percent of the reference or control that the assay uses: 55%
For compound 3 the middle estimate is 5 percentage points above the measured one, and the stated range covers the measured number.
By their numbers in this assay, from the lowest: compounds 1 and 3 (each within the scatter of the next); then compound 2.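

In this assay, among the compounds shown here, the methyl in place of hydrogen on an oxygen on an aromatic ring gives a number 15 percentage points lower from compound 2 to compound 3 (beyond the scatter) as the first reading of this change, so at this position the maximal response does not hold when hydroxy becomes methoxy. This rests on a single pair, and no measurement at hand accounts for the step. Still open, going by these compounds, is whether a propyl chain on that oxygen, or an amine in place of the hydroxy, would move the number further, and whether the step carries over to other compounds.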